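Does drawing one stereocentre shift compound 1?

The source may hold more compounds than are shown below. What is called first, only, known or untested is meant among the compounds shown, and "the series" means these compounds.

Measured so far in a physicochemical assay for lipophilicity, at pH 7.4; on this read-out higher numbers stand for higher lipophilicity and lower numbers for lower lipophilicity
- compound 1 `CCc1ccc(N(CC(C)C)S(=O)(=O)c2ccc3c(c2)C(O)CC(C2CCOCC2)O3)cc1` gives 4.12
- compound 2 `CC(C)CN(c1ccc(F)cc1)S(=O)(=O)c1ccc2c(c1)C(O)CC(C1CCOCC1)O2` gives 3.39
- compound 3 `CC(C)CN(c1ccc(C#N)cc1)S(=O)(=O)c1ccc2c(c1)C(O)CC(C1CCOCC1)O2` gives 3.07

Compound 1 holds the highest of these three numbers. Both of its gaps lie beyond the scatter: the step of a number 0.73 log units lower from compound 1 to compound 2 (beyond the scatter) is modest and the step of a number 1.05 log units lower from compound 1 to compound 3 (beyond the scatter) is large. The remaining step of a number 0.32 log units lower from compound 2 to compound 3 (beyond the scatter) is modest and also beyond the scatter.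

Compound 4 `CCc1ccc(N(CC(C)C)S(=O)(=O)c2ccc3c(c2)C(O)C[C@@H](C2CCOCC2)O3)cc1` has not been measured yet. The change from compound 1 is small (the two compounds have the same atoms and bonds; at least one stereo element is drawn with a configuration in one of them and without one in the other: 1 of 2 stereo elements differ; a stereocentre at a saturated ring carbon is drawn without a configuration in compound 1 and S in compound 4): a stereocentre at a saturated ring carbon is drawn without a configuration in compound 1 and S in compound 4. Among the measured compounds shown here, all three measured steps exchange a group on an aromatic carbon, so none bears directly on this change, and no measured pair differs only in a stereocentre. With the same atoms and bonds in both structures, compound 1 (4.12) is the best guide, and no step beyond the scatter is expected in this assay for this pair. The expected step is close to nil (no change at the digits printed from compound 1 to compound 4 (within the scatter)). Compound 4 is estimated at 4.12 with an expected range from 3.8 to 4.4 in this measurement.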

Compound 4, distribution coefficient: 4.12
Estimate against measurement, compound 4: no gap at the digits printed; measured number inside the range.
By their numbers in this assay, from the lowest: compound 3; then compound 2; then compounds 1 and 4 (each within the scatter of the next).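

Among the compounds shown here, this is the first pair that differs only in how a stereocentre is drawn, whereas the earlier steps all exchanged a group on an aromatic carbon. In this assay the result is no change at the digits printed from compound 1 to compound 4 (within the scatter), so drawing S at this saturated ring carbon leaves the read-out in place, unlike the exchanges of ethyl for fluoro or cyano. The only thing that separates this pair is a matter of stereochemical drawing: the fact that one of compounds 1 and 4 is drawn with a defined configuration and the other without, at the place where they differ.

Open, as far as these compounds go, is whether a compound drawn R at this carbon, or one with a configuration drawn at the second stereo element, would give the same number. Also open, from the compounds shown here alone, is whether this stereocentre would matter as little with an amine or a carboxylic acid in place of the ethyl on the aromatic carbon.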